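Sulfonyl Aryl Changes in a Metabotropic Glutamate Receptor Series

The source may report more compounds than this note shows. Statements on the series, on what has been measured and on what is new or still open speak of the compounds shown alone.

Measured so far:
compound 1 `CC1CCN(c2c(S(=O)(=O)c3cc(Cl)cc(Cl)c3)cnc3ccc(Cl)cc23)CC1` with 88%
compound 2 `CC1CCN(c2c(S(=O)(=O)c3ccc(Cl)c(Cl)c3)cnc3ccc(Cl)cc23)CC1` with 86%
compound 3 `COc1cccc(S(=O)(=O)c2cnc3ccc(Cl)cc3c2N2CCC(C)CC2)c1` with 87%

The three compounds share a core and differ only in the aryl group on the sulfonyl sulfur. In an assay on isolated protein for displacement of a labelled ligand from metabotropic glutamate receptor 5 (Homo sapiens), with a stated time of 60 min, tested at 1 uM (on this read-out lower numbers stand for less inhibition and higher numbers for more inhibition at the one concentration tested (going by the name of the read-out)), compound 3 sits among the others without separating from them: the step of a number 1 percentage points lower from compound 1 to compound 3 (within the scatter) and the step of a number 1 percentage points higher from compound 2 to compound 3 (within the scatter) both stay inside the scatter, as does the step of a number 2 percentage points lower from compound 1 to compound 2 (within the scatter) between the two dichlorophenyl compounds.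

Compound 4 `COc1ccc(S(=O)(=O)c2cnc3ccc(Cl)cc3c2N2CCC(C)CC2)cc1Cl` carries the change (3-chloro-4-methoxyphenyl in place of 3-methoxyphenyl on a sulfonyl sulfur). Two of the measured steps bear on it. Both start or end at the 3-methoxyphenyl compound: the step of a number 1 percentage points lower from compound 1 to compound 3 (within the scatter) and the step of a number 1 percentage points higher from compound 2 to compound 3 (within the scatter). A third, the step of a number 2 percentage points lower from compound 1 to compound 2 (within the scatter), shows that moving chlorine around the ring also left this assay unchanged. All three are within the scatter, so for compound 4 no step beyond the scatter is expected in this assay in either direction.

Compound 4 is therefore expected to give about 87% in this assay, between 78% and 94%, which means an expected step of no change at the digits printed from compound 3 to compound 4 (within the scatter).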

Compound 4, a percentage reported as inhibition, at one concentration (the size of the read-out at that concentration, not a potency): 46%
Beside the measured number, compound 4's estimate is 41 percentage points above it, and the stated range ends above it.
By their numbers in this assay, from the lowest: compound 4; then compounds 2, 3 and 1 (each within the scatter of the next).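

Among compounds 1, 2 and 3, changing the aryl group on the sulfonyl sulfur made no difference beyond the scatter in this assay, so this position looked open to change. The 3-chloro-4-methoxyphenyl group ends that picture, giving a number 41 percentage points lower from compound 3 to compound 4 (beyond the scatter) and a number 42 percentage points lower from compound 1 to compound 4 (beyond the scatter), while methoxy in place of chloro on an aromatic carbon gives a number 40 percentage points lower from compound 2 to compound 4 (beyond the scatter), so among these compounds the drop appears only where chloro and methoxy occur together in one aryl group, and neither a methoxy group as in compound 3 nor a pair of chlorines as in compound 2 is enough to produce it. No measurement in hand accounts for this drop.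

On these data alone, it remains open whether a hydroxy, ethoxy or fluoro group in place of the methoxy of the 3-chloro-4-methoxyphenyl group would give a number like that of compound 4 or like those of compounds 1, 2 and 3. As far as these compounds go, all four compounds also share one core, so whether this step holds on any other core stays open too.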